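Same Fluoro Step Repeated on a Second Core

A few compounds are considered here, and "the series" means these few. Any claim that something is new, unique, unknown or untested is made for them only; others in the source may bear on it.

Compound 1, `O=c1c(OC/C(=N/O)c2ccccc2)c(-c2ccccc2)oc2ccccc12`: in a functional assay on SK-HEP1 cells (Homo sapiens) for antiproliferative activity (on this read-out higher numbers stand for weaker inhibition of growth and lower numbers for stronger inhibition of growth), compound 1 gives 7210000 nM.
Compound 2, `O=c1c(OC/C(=N/O)c2ccc(F)cc2)c(-c2ccccc2)oc2ccccc12`: in this assay compound 2 gives 6900000 nM.
Compound 3, `O=c1c(-c2ccccc2)coc2cc(OC/C(=N/O)c3ccccc3)ccc12`: in this assay compound 3 gives 6400000 nM.

Compound 1 and compound 2 share one core, and compound 2 differs from compound 1 only in this way: fluoro in place of hydrogen on an aromatic carbon. That step gave a 1.0-fold lower number from compound 1 to compound 2 (0.02 log units; within the scatter), so the two values lie within the scatter of each other and no word of order between them is warranted.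

Compound 3 has the same atoms as compound 1 joined differently; the difference between the two cores is not broken down here. Its value sits within the scatter of both compound 1 and compound 2, so the three measured compounds cannot be told apart in this assay.

Compound 4, `O=c1c(-c2ccccc2)coc2cc(OC/C(=N/O)c3ccc(F)cc3)ccc12`, has not been measured. It differs from compound 3 in this way: fluoro in place of hydrogen on an aromatic carbon. Within the data shown here, this is the same change as the one from compound 1 to compound 2, with the same place around it. Because that earlier step gave a 1.0-fold lower number from compound 1 to compound 2 (0.02 log units; within the scatter), compound 4 is expected to stay within the scatter of compound 3, and the estimated step is a 1.0-fold lower number from compound 3 to compound 4 (0.01 log units; within the scatter). The estimate for compound 4 in this assay is 6300000 nM, expected to fall between 3500000 nM and 11000000 nM.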

Compound 4, concentration for 50% growth inhibition: 6610000 nM
Compound 4: the middle estimate sits 1.0-fold (0.02 log units) below what was measured; the range from low to high includes it.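

In this assay, the fluoro in place of hydrogen on the second core gave a 1.0-fold higher number from compound 3 to compound 4 (0.01 log units; within the scatter), so phenyl to 4-fluorophenyl left no readable difference there. Set beside the earlier step, the result on the second core agrees with that on the first: the same change on two cores in this assay, a 1.0-fold lower number (0.02 log units; within the scatter) from compound 1 to compound 2 and a 1.0-fold higher number (0.01 log units; within the scatter) from compound 3 to compound 4, 1.1-fold (0.03 log units) apart, within the scatter of two such steps. This shows that, for these two cores and in this one assay, the change carried over in the plain sense that it stayed within the scatter both times, but it does not show that a step of any real size carries from one core to another, since neither core yielded such a step, and it says nothing about cores beyond these two.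

The compounds shown hold only hydrogen or fluoro at this place on the ring, so it remains open whether a chloro, a methoxy, an amine or a carboxylic acid in the same place would move the number beyond the scatter on either core. If one did, it also remains open whether that step would be the same size on both cores.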